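Side chains on the shared core: 2-fluorobenzyl to 2-methylbenzyl

The source may report more compounds than this note shows. Statements on the series, on what has been measured and on what is new or still open speak of the compounds shown alone.

- compound 1 `COc1cc(OC)c(-c2coc3cc(OCC=C(C)C)ccc3c2=O)cc1OC`: 1090 nM
- compound 2 `C#CCOc1ccc2c(=O)c(-c3cc(OC)c(OC)cc3OC)coc2c1`: 4500 nM
- compound 3 `COc1cc(OC)c(-c2coc3cc(OCc4ccccc4F)ccc3c2=O)cc1OC`: 1610 nM

All values come from a functional assay on B16 cells (Mus musculus) for antiproliferative activity, read by MTT assay, with a stated time of 24 h; on this read-out lower numbers stand for stronger inhibition and higher numbers for weaker inhibition. Two steps place compound 3: there is a 1.5-fold higher number from compound 1 to compound 3 (0.17 log units; within the scatter), and there is a 2.8-fold lower number from compound 2 to compound 3 (0.45 log units; beyond the scatter). Compound 4 `COc1cc(OC)c(-c2coc3cc(OCc4ccccc4C)ccc3c2=O)cc1OC` carries methyl in place of fluoro on an aromatic carbon, ortho to a large group: methyl in place of fluoro on an aromatic carbon. Going by the values given here, no measured step makes this exchange. Among the compounds with values here, the closest evidence is those same two steps, which replace the whole group on the saturated chain carbon, and only the one involving compound 2 leaves the scatter. No shift beyond the scatter is therefore expected in this assay. The expected change is a 1.1-fold lower number from compound 3 to compound 4 (0.03 log units; within the scatter). Compound 4 is estimated at 1500 nM, with an expected range of 720 nM to 3200 nM.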

Compound 4, half-maximal inhibitory concentration: 2150 nM
Compound 4: the middle estimate sits 1.4-fold (0.16 log units) below what was measured, within the range that was stated.
By their numbers in this assay, from the lowest: compounds 1, 3 and 4 (each within the scatter of the next); then compound 2.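

In this assay, going by these compounds alone, methyl in place of fluoro on this aromatic carbon gives a 1.3-fold higher number from compound 3 to compound 4 (0.13 log units; within the scatter) and is the first direct reading of this exchange, which leaves 2-fluorobenzyl and 2-methylbenzyl not separated. In place of ethynyl, 2-methylphenyl gives a 2.1-fold lower number from compound 2 to compound 4 (0.32 log units; beyond the scatter) while in place of 2-methylprop-1-en-1-yl it gives a 2.0-fold higher number from compound 1 to compound 4 (0.30 log units; within the scatter) and so compound 4 reads like compound 3 in both comparisons. No supporting measurement accompanies these steps.

Open, from the compounds shown here alone, is whether an amine or a carboxylic acid on this aromatic carbon would give a step beyond the scatter.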